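Swapping the Aryl Group: From Compound 2 to Compound 3

The source may report more compounds than this note shows. Statements on the series, on what has been measured and on what is new or still open speak of the compounds shown alone.

Compound 1 `COC(=O)c1cc(NC2=NC(=O)/C(=C/c3ccc(C)cc3)S2)ccc1O`: 450 nM
Compound 2 `COC(=O)c1cc(NC2=NC(=O)/C(=C/c3ccccc3O)S2)ccc1O`: 3440 nM

In a functional assay on HCT-116 cells (Homo sapiens) for antiproliferative activity, read by sulforhodamine B assay, with a stated time of 48 h (a lower number here means a stronger inhibitor, a higher number a weaker inhibitor), compound 2 gives the higher of the two numbers; compound 1 sits a 7.6-fold higher number from compound 1 to compound 2 (0.88 log units; beyond the scatter) away in the other direction. Compound 3 `COC(=O)c1cc(NC2=NC(=O)/C(=C/c3ccc(Br)cc3)S2)ccc1O` differs from compound 2 by 4-bromophenyl in place of 2-hydroxyphenyl on a double-bonded chain carbon bound to a double-bonded ring carbon. Going by the values given here, the one step that bears on this change is the same pairing in reverse, from 4-methylphenyl to 2-hydroxyphenyl, which was a 7.6-fold higher number from compound 1 to compound 2 (0.88 log units; beyond the scatter). Since 4-bromophenyl, like 4-methylphenyl, carries neither hydrogen-bond donor nor acceptor, compound 3 is expected to move back toward compound 1, an estimated 6.3-fold lower number from compound 2 to compound 3 (0.80 log units; beyond the scatter). The expected value for compound 3 is therefore 550 nM, within 150 nM to 2000 nM.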

Compound 3, half-maximal inhibitory concentration: 5580 nM
Compound 3: middle estimate off by 10-fold (1.01 log units), on the low side; the whole stated range lies below it.
By their numbers in this assay, from the lowest: compound 1; then compounds 2 and 3 (each within the scatter of the next).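

In this assay, 4-bromophenyl did not bring the number back toward compound 1: a 1.6-fold higher number from compound 2 to compound 3 (0.21 log units; within the scatter), so compound 2 and compound 3 cannot be told apart, although the hydrogen-bond donor and acceptor of 2-hydroxyphenyl are gone. Bromo in place of methyl on an aromatic carbon instead gives a 12-fold higher number from compound 1 to compound 3 (1.09 log units; beyond the scatter), so among these three compounds, having no donor or acceptor on this aryl group does not by itself go with a low number. Nothing available explains this. As far as these compounds go, it remains open whether the low number of compound 1 is specific to methyl, or whether an ethyl, methoxy or amino group in that place would read the same.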